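Swapping fluoro for bromo on compound 2

A few compounds are considered here, and "the series" means these few. Any claim that something is new, unique, unknown or untested is made for them only; others in the source may bear on it.

Three related compounds have been measured in a functional assay on the whole organism for positive allosteric modulation, with Mus musculus as the target; on this read-out lower numbers stand for an effect already at smaller amounts and higher numbers for an effect only at larger amounts of compound. Compound 1 `CCC(=O)N(c1ccc(Cl)c(Cl)c1)C1CCCC1O` gives 20 mg/kg, compound 2 `CCC(=O)N(c1cccc(F)c1)C1CCCC1N(C)C` gives 5 mg/kg, and compound 3 `CCC(=O)N(c1ccc(C)c(Cl)c1)C1CCCC1N(C)C` gives 2 mg/kg. Compound 2 therefore stands in the middle of the three, with compound 3 lower and compound 1 higher, and both gaps lie beyond the usual scatter.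

The next compound, compound 4 `CCC(=O)N(c1cccc(Br)c1)C1CCCC1N(C)C`, differs from compound 2 in one place: bromo in place of fluoro on an aromatic carbon. In words, this is bromo in place of fluoro on an aromatic carbon. For the measured compounds named here, no measured pair shows this exchange alone, so the data offer no direct guide. Going by the values given here, the one hint is compound 3 at 2 mg/kg, which differs from compound 2 on the same aromatic ring, among other changes, and has the lower number.

The expected change is a 1.7-fold lower number from compound 2 to compound 4 (0.22 log units; within the scatter), a small move toward lower numbers in this assay and probably none beyond the scatter. For compound 4 the estimate is 3 mg/kg, with an expected range of 1 mg/kg to 8 mg/kg.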

Compound 4, dose for half-maximal effect: 2 mg/kg
For compound 4 the middle estimate is 1.5-fold (0.18 log units) above the measured one, and the stated range covers the measured number.
By their numbers in this assay, from the lowest: compounds 3 and 4 (each within the scatter of the next); then compound 2; then compound 1.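

In this assay bromo in place of fluoro on this aromatic carbon gives a 2.5-fold lower number from compound 2 to compound 4 (0.40 log units; beyond the scatter) and, small as the exchange is, that step lies beyond the usual scatter. This is the only pair shown that differs in one place, so it is the first direct sign that the read-out responds to which halogen sits at this position, something the earlier compounds, which differ in several places at once, could not show. Nothing measured here says why the number moves.

The compounds shown leave open how a methoxy group, a nitrile or a trifluoromethyl group on this same carbon would compare with bromo. They also leave open whether the same exchange would give a similar step on a core that carries a hydroxyl group in place of the dimethylamino group.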